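The source may hold more compounds than are shown below. What is called first, only, known or untested is meant among the compounds shown, and "the series" means these compounds.

Three compounds share one core and differ only in the group carried on the amide-type nitrogen. Compound 1 `COc1cccc(OC)c1C(=O)Nc1c[nH]nc1C(=O)NC1CC1` bears a cyclopropyl there, compound 2 `COc1cccc(OC)c1C(=O)Nc1c[nH]nc1C(=O)NCC1CCCCC1` a cyclohexylmethyl, and compound 3 `COc1cccc(OC)c1C(=O)Nc1c[nH]nc1C(=O)NCCN1CCCC1` a 2-(pyrrolidin-1-yl)ethyl. All three were tested in an ADME assay on MRC5 cells (Homo sapiens) for inhibition, with a stated time of 72 h; on this read-out higher numbers stand for an effect only at larger amounts of compound and lower numbers for an effect already at smaller amounts. Compound 1 reaches only a limit of the assay, > 50000 nM. Compound 2 likewise gives a limit, > 50000 nM. Compound 3 also stops at a limit, > 50000 nM. Because every value sits at the limit of > 50000 nM in this assay, at which 3 of the 3 values shown sit, none of the steps between them can be read: a step that the two limits leave unreadable from compound 1 to compound 2, a step that the two limits leave unreadable from compound 1 to compound 3 and a step that the two limits leave unreadable from compound 2 to compound 3 all remain unreadable. Compound 3 therefore stands where the other two stand, at a limit rather than a number.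

Compound 4 `COc1cccc(OC)c1C(=O)Nc1c[nH]nc1C(=O)Nc1ccccn1` has not yet been measured. It differs from compound 3 as follows: pyridin-2-yl in place of 2-(pyrrolidin-1-yl)ethyl on an amide-type nitrogen. Among the measured compounds shown here, no measured step bears on this change in a readable way, since the limit hides all three steps between the measured compounds. The expectation for compound 4 rests only on the fact that compound 1, compound 2 and compound 3 all sit at the limit of > 50000 nM in this assay, at which 3 of the 3 values shown sit. The step expected from this change is a number no higher from compound 3 to compound 4 (the limit leaves the size open), none beyond the scatter. The estimated value for compound 4 in this assay is 50000 nM, with a range from 20000 nM to 150000 nM.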

Compound 4, half-maximal effective concentration: > 50000 nM
Compound 4: no number, only a limit; the forecaster's own chance of this, stated with the estimate: 85%; the middle value lies on the limit itself.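

In this assay compound 4 gives > 50000 nM as a limit and not a number. Among the compounds shown here, no step from compound 1, compound 2 or compound 3 to compound 4 can be read, because all four stop at the same limit: the limit of > 50000 nM in this assay, at which 4 of the 4 values shown sit. The compounds shown leave open at what amount any of them would act in this assay and whether the group on the amide-type nitrogen changes that amount.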